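This account rests on a few compounds, and the source may have more. Where it says the series, first, only, none or still open, it means among the compounds named here.

In a functional assay on the whole organism for agonist activity, with Mus musculus as the target (a higher number here means that more compound is needed for the effect, a lower number that less compound is needed), compound 3 (`CCOC(=O)N(C)C(C)C#CCN1CCCC1`) stands at the limit of > 100 mg/kg in this assay, at which 2 of the 3 values shown sit: its > 100 mg/kg is a limit, not a number. Compound 2 (`CCOC(=O)N(C)CC#CCn1ccnc1`) gives > 100 mg/kg, also a limit. Among the compounds with values here, compound 1 (`CC(=O)N(C)C(C)C#CCn1ccnc1`) is the only one with a measured number, 3 mg/kg.

Compound 4 (`CCOC(=O)N(C)C(C)C#CCn1ccnc1`) has 1H-imidazol-1-yl in place of pyrrolidin-1-yl on a saturated chain carbon bound to a triple-bonded carbon. Compound 1 also carries 1H-imidazol-1-yl and gives 3 mg/kg, which favours a lower dose in this assay. Compound 2 carries the same group yet reaches no number, so only a modest shift is expected. The expected at least 2.5-fold lower number from compound 3 to compound 4 (0.39 log units; beyond the scatter) points towards a lower dose. For compound 4 the estimate is 40 mg/kg, with an expected range of 8 mg/kg to 100 mg/kg.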

Compound 4, dose for half-maximal effect: > 100 mg/kg
Compound 4 ended at the assay's limit; the forecaster's own chance of this, stated with the estimate: 50%; middle value at least 2.5-fold (0.39 log units) from the limit.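

In this assay, 1H-imidazol-1-yl on the chain does not by itself give a measurable dose: with that ring and the chain methyl unchanged, ethoxy in place of methyl on a carbonyl carbon gives an at least 33-fold higher number from compound 1 to compound 4 (1.52 log units; beyond the scatter). Compound 4 gives > 100 mg/kg, a limit and not a number, and the steps to it from compound 2 and compound 3 cannot be read. All compounds with ethoxy on the carbonyl carbon sit at this limit, and only compound 1, with methyl there, goes against it: the limit of > 100 mg/kg in this assay, at which 3 of the 4 values shown sit.

From the compounds shown here alone, whether pyrrolidin-1-yl also gives a measurable dose with methyl on the carbonyl carbon stays open. So does the outcome with an amine or a propyl chain on that carbon.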